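Amide Swap on a Fused Core Against Prostate Cancer Cells

The compounds below may be only part of what the source reports. "The series", "measured", "known", "first", "only" and "open" are said of these compounds alone.

Measured compounds:
compound 1, `C=C(C)C(=O)Nc1cc2c(N3CCc4ccccc43)ncnc2cc1OC`: 4830 nM
compound 2, `COc1cc2ncnc(N3CCc4ccccc43)c2cc1NC(=O)/C=C/C(C)C`: 6530 nM
compound 3, `C=C(C)C(=O)Nc1cc2c(N3CCc4ccccc43)ncnc2cc1O[C@@H]1CCOC1`: 4910 nM

In a functional assay on PC-3 cells (Homo sapiens) for antiproliferative activity, read by MTT assay, with a stated time of 72 h (a lower number here means a stronger inhibitor, a higher number a weaker inhibitor), compound 3 gives 4910 nM, the second highest of the three numbers; its neighbours lie close, a 1.0-fold higher number from compound 1 to compound 3 (0.01 log units; within the scatter) and compound 2 sitting within the scatter of it. Compound 4, `CN(C)C/C=C/C(=O)Nc1cc2c(N3CCc4ccccc43)ncnc2cc1O[C@@H]1CCOC1`, differs from compound 3 in one place: 3-(dimethylamino)prop-1-en-1-yl in place of 1-methylethenyl on a carbonyl carbon. Among the compounds with values here, the only measured step on the same carbonyl carbon, a 1.4-fold higher number from compound 1 to compound 2 (0.13 log units; within the scatter), was within the scatter, and so was the switch on the ring oxygen. Within the data shown here, no measured step therefore supports a shift beyond the scatter, and the expected step of a 1.2-fold lower number from compound 3 to compound 4 (0.09 log units; within the scatter) is small. Compound 4 is expected to give 4000 nM, with a range from 1300 nM to 12000 nM.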

Compound 4, half-maximal inhibitory concentration: 1230 nM
Beside the measured number, compound 4's estimate is 3.3-fold (0.51 log units) above it; the whole stated range lies above it.
By their numbers in this assay, from the lowest: compound 4; then compounds 1, 3 and 2 (each within the scatter of the next).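

In this assay this carbonyl carbon turns out to be sensitive to what it carries: 3-(dimethylamino)prop-1-en-1-yl in place of 1-methylethenyl gave a 4.0-fold lower number from compound 3 to compound 4 (0.60 log units; beyond the scatter) and moved the number beyond the scatter, whereas 3-methylbut-1-en-1-yl, with no nitrogen, gave only a 1.4-fold higher number from compound 1 to compound 2 (0.13 log units; within the scatter) and stayed within it. Among these compounds, only the chain holding the dimethylamino group goes with the lower number. Nothing measured here explains this step. Going by these compounds, whether a cyclic amine such as piperidine or a longer chain before the amine would do the same remains open. So does whether this chain gives a similar step with methyl on the ring oxygen.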